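The compounds below may be only part of what the source reports. "The series", "measured", "known", "first", "only" and "open" are said of these compounds alone.

Measured so far in an ADME assay on microsomes from liver (Homo sapiens) for metabolic stability; on this read-out lower numbers stand for a shorter-lived compound and higher numbers for a longer-lived compound:
Compound 1 (`Cc1cccc(NC(=O)c2nn(C)c(-c3ccc(F)cc3)c2C)n1`) : 1.37 h
Compound 2 (`Cc1nc(C(=O)Nc2cccc(F)n2)c(C)n1-c1ccc(F)cc1`) : 1.6 h

Among the compounds with values here, with only two measurements, compound 2 at 1.6 h has a single neighbour, compound 1 at 1.37 h, and the two numbers lie within the usual scatter of each other, so neither can be ranked above the other in this assay as it stands.

Compound 3 (`Cc1nc(NC(=O)c2nc(C)n(-c3ccc(F)cc3)c2C)ccc1F`) is the next to be read. It carries 5-fluoro-6-methylpyridin-2-yl in place of 6-fluoropyridin-2-yl on an amide-type nitrogen and is otherwise the same as compound 2.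

Within the data shown here, no measured pair isolates this change, so the data offer no direct guide to it. The expectation rests only on the closeness of the two values already in hand. Only a small change is expected, an estimated 1.1-fold lower number from compound 2 to compound 3 (0.06 log units; within the scatter) that stays within the scatter, with no firm direction. In this assay compound 3 is estimated at 1.4 h and expected to fall between 0.7 h and 2.8 h on repeated measurement.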

Compound 3, half-life: 1 h
The estimate for compound 3 lay 1.4-fold (0.15 log units) above the measured number; measured number inside the range.
By their numbers in this assay, from the lowest: compounds 3, 1 and 2 (each within the scatter of the next).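

The series now has its first step at the amide-type nitrogen in this assay: putting 5-fluoro-6-methylpyridin-2-yl in place of 6-fluoropyridin-2-yl gives a 1.6-fold lower number from compound 2 to compound 3 (0.20 log units; within the scatter). This single pair therefore shows that exchanging these two fluorinated pyridinyl groups, with the rest of the structure kept the same, does not separate the compounds beyond the usual scatter of the half-life measurement. Nothing available bears on what lies behind this result, so the step can be reported only as a measured comparison.

The exchange alters the group in two ways at once, since the names of the two groups differ in both the methyl group and the placement of the fluorine, so this pair cannot assign any share of the step to either feature. Compound 1 differs from compound 3 in more than one place and cannot help here. As far as these compounds go, it also remains open whether a more different group on the same amide-type nitrogen, such as a pyridin-2-yl ring carrying a methoxy group or a nitrile, would move the half-life beyond the scatter.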